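From pyridin-4-yl to pyridin-3-yl on a shared core

The compounds below may be only part of what the source reports. "The series", "measured", "known", "first", "only" and "open" are said of these compounds alone.

Measured so far:
- compound 1, `COc1cncc(-c2c(C)nn(-c3nc(-c4ccc(Cl)c(Cl)c4)c(SC(C)C)s3)c2C(=O)O)c1`, 21000 nM
- compound 2, `Cc1nn(-c2nc(-c3ccc(Cl)c(Cl)c3)c(SC(C)C)s2)c(C(=O)O)c1-c1cccc(C(F)(F)F)c1`, 22000 nM
- compound 3, `Cc1nn(-c2nc(-c3ccc(Cl)c(Cl)c3)c(SC(C)C)s2)c(C(=O)O)c1-c1ccncc1`, 5900 nM

All three were tested in a functional assay on BJAB cells (Homo sapiens) for antiproliferative activity, with a stated time of 4 days; on this read-out higher numbers stand for an effect only at larger amounts of compound and lower numbers for an effect already at smaller amounts. Compound 3 gives the lowest number of the three, and both gaps to it are beyond the scatter: a 3.6-fold lower number from compound 1 to compound 3 (0.55 log units; beyond the scatter) and a 3.7-fold lower number from compound 2 to compound 3 (0.57 log units; beyond the scatter). Compound 1 and compound 2 are within the scatter of each other, so no order between them can be read (a 1.0-fold higher number from compound 1 to compound 2 (0.02 log units; within the scatter)).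

Compound 4, `Cc1nn(-c2nc(-c3ccc(Cl)c(Cl)c3)c(SC(C)C)s2)c(C(=O)O)c1-c1cccnc1`, differs from compound 3 by a small rearrangement: pyridin-3-yl in place of pyridin-4-yl on an aromatic carbon. The earlier steps shown here swapped a whole different ring in at this position and moved the number by a modest amount; here the ring stays a pyridine and only the nitrogen position changes. Going by the values given here, there is no measured pair that isolates this exact move, so the expectation rests on the modest size of the steps into compound 3 and on the smallness of the change. The expected step of a 1.5-fold higher number from compound 3 to compound 4 (0.18 log units; within the scatter) is a slight rise, with a fair chance of lying within the scatter. Compound 4 is estimated at 9000 nM in this assay, with a plausible range from 3000 nM to 27000 nM.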

Compound 4, half-maximal effective concentration: 12000 nM
Estimate against measurement, compound 4: 1.3-fold (0.12 log units) below; the measured number falls inside the stated range.
By their numbers in this assay, from the lowest: compound 3; then compounds 4, 1 and 2 (each within the scatter of the next).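

In this assay, moving the nitrogen to another place in the pyridine ring, with the same atoms simply joined differently, is enough to show: a 2.0-fold higher number from compound 3 to compound 4 (0.31 log units; beyond the scatter). This step is modest, but it shows that this position, on an aromatic carbon of the five-membered ring, can register a change in where the ring nitrogen sits, not only the exchange of one ring for a different one. Compound 4 does not separate from the other two, as both a 1.8-fold lower number from compound 2 to compound 4 (0.26 log units; within the scatter) and a 1.8-fold lower number from compound 1 to compound 4 (0.24 log units; within the scatter), so compound 3, with its pyridin-4-yl group, is the only one of the four that stands apart, and no measurement at hand explains why the nitrogen's place matters.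

The compounds shown leave open how pyridin-2-yl, the remaining way of attaching a pyridine ring here, would compare with pyridin-4-yl and pyridin-3-yl. They also leave open whether a methoxy group or an amine added to the pyridin-4-yl ring would keep the number of compound 3 or bring it back towards those of the others.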